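This account rests on a few compounds, and the source may have more. Where it says the series, first, only, none or still open, it means among the compounds named here.

In a functional assay on K562 cells (Homo sapiens) for inhibition, read by sulforhodamine B assay, with a stated time of 48 h, tested at 10 uM (a lower number here means a stronger effect, a higher number a weaker effect of the compound at the concentration tested), compound 2 `COc1cc2cc(Oc3ccc(NC(=O)Nc4cccc(C(F)(F)F)c4)cc3)c(C)nc2cc1OC` gives 11.5%, the lowest of the two numbers measured; compound 1 `COc1cc2cc(Oc3ccc(NC(=O)Nc4ccc(C(F)(F)F)cc4)cc3)c(C)nc2cc1OC` gives 57.1%. Among the measured compounds shown here, the single recorded step, a number 45.6 percentage points lower from compound 1 to compound 2 (beyond the scatter), moves the trifluoromethyl group to another position and does not add a substituent. Compound 3 `COc1cc2cc(Oc3ccc(NC(=O)Nc4ccc(Cl)c(C(F)(F)F)c4)cc3)c(C)nc2cc1OC` differs from compound 2 by chloro in place of hydrogen on an aromatic carbon. For the measured compounds named here, no measured step covers an added chloro on this ring, so neither direction nor size can be read from the data. The expected step is a number 6.5 percentage points higher from compound 2 to compound 3 (within the scatter), within the scatter, with a wide range. For compound 3 the estimate is 18%, from 4% to 50%.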

Compound 3, a percentage reported as activity, at one concentration (the size of the read-out at that concentration, not a potency): -9.54%
Compound 3: middle estimate off by 27.5 percentage points, on the high side, outside the stated range (below it).
By their numbers in this assay, from the lowest: compound 3; then compound 2; then compound 1.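

In this assay, chloro on the aromatic carbon ortho to a trifluoromethyl group and para to a large group goes with a stronger effect, a number 21 percentage points lower from compound 2 to compound 3 (beyond the scatter), so this position accepts the added atom without loss. 4-Chloro-3-(trifluoromethyl)phenyl in place of 4-(trifluoromethyl)phenyl gives the largest step in the series, a number 66.6 percentage points lower from compound 1 to compound 3 (beyond the scatter). Nothing available bears on the reason for the chloro step.

Open, going by these compounds, is whether a methoxy group, an amine or a carboxylic acid at this carbon keeps the effect. Also open, on these data alone, is whether compound 3 keeps its rank at lower concentrations.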